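The compounds below may be only part of what the source reports. "The series", "measured", "known", "first", "only" and "open" are said of these compounds alone.

In an ADME assay on MT4 cells (Homo sapiens) for cytotoxicity, read by MTT assay (on this read-out lower numbers stand for higher toxicity in this test and higher numbers for lower toxicity in this test), compound 1 (`O=C(CSc1nncnc1-c1ccccc1Cl)c1ccc(Cl)c(Cl)c1`) gives 33000 nM and compound 2 (`O=C(CSc1nncnc1-c1ccccc1Cl)c1ccc(Br)cc1Br`) gives 28000 nM on the same scale. Compound 3 (`COC(=O)c1sccc1NC(=O)CSc1nncnc1-c1ccccc1Cl`) stands highest of the three at 105000 nM and lies beyond the scatter from both others. Compound 4 (`O=C(CSc1nncnc1-c1ccccc1Cl)Nc1ccccn1`) carries pyridin-2-yl in place of 2-(methoxycarbonyl)thiophen-3-yl on an amide-type nitrogen. For the measured compounds named here, the one measured step (a 1.2-fold lower number from compound 1 to compound 2 (0.07 log units; within the scatter)) lies within the scatter and sits on a carbonyl carbon, so it offers no direct guide to a change on this nitrogen. The expectation therefore rests on the spread of values alone: compound 3 sits at the top at 105000 nM and the other two lie lower. In this assay a modest move to a lower number is expected (a 1.6-fold lower number from compound 3 to compound 4 (0.21 log units; within the scatter)), though with so little data a wide margin is needed. The estimate for compound 4 is 65000 nM with an expected range (22000 nM to 180000 nM).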

Compound 4, half-maximal cytotoxic concentration: 172000 nM
Compound 4: the middle estimate sits 2.6-fold (0.42 log units) below what was measured, and the stated range covers the measured number.
By their numbers in this assay, from the lowest: compounds 2 and 1 (each within the scatter of the next); then compounds 3 and 4 (each within the scatter of the next).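

Measured in this assay the change on the amide-type nitrogen gives a 1.6-fold higher number from compound 3 to compound 4 (0.21 log units; within the scatter) so pyridin-2-yl and 2-(methoxycarbonyl)thiophen-3-yl cannot be told apart here, even though the methoxycarbonyl group leaves with the thiophene. Larger gaps appear only at the carbonyl carbon: (pyridin-2-yl)amino in place of 2,4-dibromophenyl gives a 6.1-fold higher number from compound 2 to compound 4 (0.79 log units; beyond the scatter) and in place of 3,4-dichlorophenyl gives a 5.2-fold higher number from compound 1 to compound 4 (0.72 log units; beyond the scatter) and both steps lie beyond the scatter, towards lower toxicity in this test, which the earlier swap between those two aryl groups did not show. Nothing available explains these steps.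

From the compounds shown here alone, it stays open how a plain phenyl, a cyclohexyl or a carboxylic acid-bearing chain on this nitrogen would read. Going by these compounds, it also stays open whether the higher numbers go with the amide link itself or with the particular rings attached to it.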